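The source may report more compounds than this note shows. Statements on the series, on what has been measured and on what is new or still open speak of the compounds shown alone.

Compound 1 `CC(C)c1ccc(-c2nc(SCc3cn(CC(=O)NC(=O)Nc4ccccn4)nn3)nc(Nc3ccccc3Cl)c2C#N)cc1`: 6790 nM
Compound 2 `CC(C)c1ccc(-c2nc(SCc3cn(CC(=O)NC(=O)Nc4ccccn4)nn3)nc(Nc3cccc(Cl)c3)c2C#N)cc1`: 1130 nM
Compound 3 `Cc1ccc(Nc2nc(SCc3cn(CC(=O)NC(=O)Nc4ccccn4)nn3)nc(-c3ccc(C(C)C)cc3)c2C#N)cc1`: 3060 nM

In a functional assay on B16-F10 cells (Mus musculus) for inhibition, read by MTT assay, with a stated time of 72 h (a lower number here means a stronger inhibitor, a higher number a weaker inhibitor), compound 3 holds the second highest of the three numbers: compound 1 sits above it, as a 2.2-fold lower number from compound 1 to compound 3 (0.35 log units; beyond the scatter) shows, and compound 2 below it, as a 2.7-fold higher number from compound 2 to compound 3 (0.43 log units; beyond the scatter) shows. Compound 4 `Cc1cccc(Nc2nc(SCc3cn(CC(=O)NC(=O)Nc4ccccn4)nn3)nc(-c3ccc(C(C)C)cc3)c2C#N)c1` differs from compound 3 only by 3-methylphenyl in place of 4-methylphenyl on a nitrogen on an aromatic ring. For the measured compounds named here, no measured pair carries exactly this change. The nearest guide is a 6.0-fold lower number from compound 1 to compound 2 (0.78 log units; beyond the scatter), where moving the chlorine of the anilino group gave a clear gain, and a 2.7-fold higher number from compound 2 to compound 3 (0.43 log units; beyond the scatter), where the 3-chlorophenyl outscored the 4-methylphenyl. With only chloro analogues to go on, a modest drop in number is expected for compound 4, estimated at 1800 nM (range 800 nM to 4000 nM), that is a 1.7-fold lower number from compound 3 to compound 4 (0.23 log units; within the scatter).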

Compound 4, half-maximal inhibitory concentration: 1650 nM
Beside the measured number, compound 4's estimate is 1.1-fold (0.04 log units) above it, within the range that was stated.
By their numbers in this assay, from the lowest: compounds 2, 4 and 3 (each within the scatter of the next, the first and the last beyond it); then compound 1.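

In this assay, 3-methylphenyl and 4-methylphenyl on this nitrogen cannot be told apart (a 1.9-fold lower number from compound 3 to compound 4 (0.27 log units; within the scatter)), and neither can methyl and chloro on the aromatic carbon (a 1.5-fold higher number from compound 2 to compound 4 (0.16 log units; within the scatter)). Compound 1 stays the weakest, now also against the 3-methylphenyl compound (a 4.1-fold lower number from compound 1 to compound 4 (0.61 log units; beyond the scatter)), so among the four compounds the 2-chlorophenyl group alone stands apart from every other. No measurement shown here explains these steps. The compounds shown leave open how 2-methylphenyl would compare with 2-chlorophenyl on this nitrogen, and how a 3-methoxyphenyl or 3-aminophenyl group would compare with 3-methylphenyl.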